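A few compounds are considered here, and "the series" means these few. Any claim that something is new, unique, unknown or untested is made for them only; others in the source may bear on it.

Three measured compounds share one core and differ only in the aryl group attached to the nitrogen on the aromatic ring. Compound 1 `COc1cc(N(CC2CC2)c2ccc(Cl)c(Cl)c2)cnc1C(=O)[C@H]1C[C@@H]1C(=O)O` carries a 3,4-dichlorophenyl there, and in an assay on isolated protein for inhibition of leukotriene C4 synthase (Homo sapiens), read by LC-MS, with stated times of 45 min and 20 min (a lower number here means a stronger inhibitor, a higher number a weaker inhibitor), compound 1 gives 27.7 nM. Compound 2 `COc1cc(N(CC2CC2)c2ccc(F)c3ccccc23)cnc1C(=O)[C@H]1C[C@@H]1C(=O)O` carries a different, fluorine-bearing aryl group, and compound 2 gives 26.5 nM. Compound 3 `COc1cc(N(CC2CC2)c2cccc(C(F)(F)F)c2)cnc1C(=O)[C@H]1C[C@@H]1C(=O)O` carries a 3-(trifluoromethyl)phenyl, and compound 3 gives 52.4 nM. Compound 3 shows the highest number of the three, but the step of a 1.9-fold higher number from compound 1 to compound 3 (0.28 log units; within the scatter) lies within the scatter, and its gap to compound 2 is within the scatter as well, so the three numbers cannot be put in order.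

Compound 4 `CCCN(c1cccc(C(F)(F)F)c1)c1cnc(C(=O)[C@H]2C[C@@H]2C(=O)O)c(OC)c1` keeps the aryl group of compound 3 and changes the other substituent on the same nitrogen: ethyl in place of cyclopropyl on a saturated chain carbon bound to a nitrogen on an aromatic ring. Among the measured compounds shown here, no measured step touches this part of the molecule, since all three measured compounds carry the cyclopropylmethyl group; the only step on record, from compound 1 to compound 3, concerns the aryl group and stayed within the scatter. With no direct guide, the expected step of a 1.1-fold higher number from compound 3 to compound 4 (0.06 log units; within the scatter) is estimated to stay within the scatter, in no particular direction. Compound 4 is therefore expected to give about 60 nM, with a range from 25 nM to 150 nM.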

Compound 4, half-maximal inhibitory concentration: 58.4 nM
Compound 4: middle estimate off by 1.0-fold (0.01 log units), on the high side; measured number inside the range.
By their numbers in this assay, from the lowest: compounds 2, 1, 3 and 4 (each within the scatter of the next, the first and the last beyond it).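

Among the compounds shown here, until now, every measured change concerned the aryl group, so this is the first step that touches the other substituent on the nitrogen. In this assay, the step of a 1.1-fold higher number from compound 3 to compound 4 (0.05 log units; within the scatter) comes from replacing cyclopropyl with ethyl, which removes the three-membered ring and turns cyclopropylmethyl into propyl, yet the two numbers cannot be told apart. With the 3-(trifluoromethyl)phenyl group in place, the closed ring is therefore not required for a number in this range, and nothing on hand explains this result.

From the compounds shown here alone, this conclusion rests on a single pair, so it remains open whether the same change would leave the number just as undisturbed with the 3,4-dichlorophenyl group of compound 1 or the fluorine-bearing aryl group of compound 2. Also open, going by these compounds, is how far this substituent can vary, for example with a longer chain such as butyl, a branched chain such as isopropyl, or a chain ending in an amine or a hydroxyl group.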